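A few compounds are considered here, and "the series" means these few. Any claim that something is new, unique, unknown or untested is made for them only; others in the source may bear on it.

Working notes on the series. Among the measured compounds shown here, compound 1 `CC(C)(C)c1ccc(CNCCNS(=O)(=O)c2cc(C(F)(F)F)cc(C(F)(F)F)c2)cc1` is the weakest of the three measured members: in a functional assay on BE(2)-C cells (Homo sapiens) for inhibition, read by MTT assay, with a stated time of 72 h (on this read-out lower numbers stand for stronger inhibition of growth and higher numbers for weaker inhibition of growth), compound 1 gives 14000 nM. For the measured compounds named here, compound 2 `O=S(=O)(NCCNCc1ccc(-c2ccccc2)cc1)c1cc(C(F)(F)F)cc(C(F)(F)F)c1` gives 2700 nM in this assay, and the single one-place step in the set, a 5.2-fold lower number from compound 1 to compound 2 (0.71 log units; beyond the scatter), is the only measured comparison available. Compound 3 `COc1ccc(CNCCCNS(=O)(=O)c2cc(C(F)(F)F)cc(C(F)(F)F)c2)cc1OC` gives 3600 nM in this assay; among the three numbers it stands second highest, within the scatter of compound 2 and clearly below the number of compound 1.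

Compound 4 `COc1ccccc1CNCCCNS(=O)(=O)c1cc(C(F)(F)F)cc(C(F)(F)F)c1` differs from compound 3 in one place, (2-methoxyphenyl in place of 3,4-dimethoxyphenyl on a saturated chain carbon bound to an amine nitrogen). Going by the values given here, no measured step in the set touches the methoxy pattern of the benzyl group; the one step known, a 5.2-fold lower number from compound 1 to compound 2 (0.71 log units; beyond the scatter), concerns a different substituent on the same ring and gives no guide to size or direction for this change. With nothing to point either way, the expectation in this assay for compound 4 is a step that stays within the scatter, a 1.1-fold higher number from compound 3 to compound 4 (0.05 log units; within the scatter). Among the compounds with values here, compound 4 is therefore estimated at 4000 nM, with a range from 1500 nM to 11000 nM, the width reflecting that a change of this kind has no precedent among the measured compounds.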

Compound 4, concentration for 50% growth inhibition: 3600 nM
Estimate against measurement, compound 4: 1.1-fold (0.05 log units) above; low and high end bracket the measured number.
By their numbers in this assay, from the lowest: compounds 2, 3 and 4 (each within the scatter of the next); then compound 1.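

In this assay, among the compounds shown here, the change from 3,4-dimethoxybenzyl to 2-methoxybenzyl gives no change at the digits printed from compound 3 to compound 4 (within the scatter) and is the only measured step that alters the methoxy pattern on a saturated chain carbon bound to an amine nitrogen. For the compounds shown here, the aryl group goes to fewer heavy atoms and fewer hydrogen-bond acceptors with no shift that can be read in this assay, in contrast to the one other measured step, which is a 5.2-fold lower number from compound 1 to compound 2 (0.71 log units; beyond the scatter) and concerns a different substituent on compounds with a different chain. No measurement at hand bears on why the number holds across this change.

The single step alters the number of methoxy groups and their placement together, so the compounds shown do not separate the two contributions. Also open are how an unsubstituted phenyl, a chlorophenyl or a hydroxyphenyl would read at this place, and what a longer chain would do, since no pair shown differs in chain length alone.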